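Sugar-linked triazole series: furanose to pyranose step

The source may report more compounds than this note shows. Statements on the series, on what has been measured and on what is new or still open speak of the compounds shown alone.

Within the data shown here, only two numbers are recorded so far in a functional assay on A-375 cells (Homo sapiens) for cytotoxicity, read by MTT assay, with a stated time of 72 h; on this read-out lower numbers stand for stronger inhibition and higher numbers for weaker inhibition. Compound 2 `O=C1c2c[n+]([O-])c3ccccc3c2C(=O)c2c1c1ccccc1n2Cc1cn([C@H]2O[C@H](CO)[C@@H](O)[C@H]2O)nn1` gives 340 nM, and compound 1 `CC1(C)O[C@@H](CO)[C@H](Cn2cc(Cn3c4c(c5ccccc53)C(=O)c3c[n+]([O-])c5ccccc5c3C4=O)nn2)O1` gives 190 nM; the step of a 1.8-fold higher number from compound 1 to compound 2 (0.25 log units; within the scatter), so compound 2 stands alongside compound 1 inside the scatter rather than apart from it. Compound 3 `O=C1c2c[n+]([O-])c3ccccc3c2C(=O)c2c1c1ccccc1n2Cc1cn([C@@H]2O[C@H](CO)[C@@H](O)[C@H](O)[C@H]2O)nn1` is not yet measured. Relative to compound 2 the change is 3,4,5-trihydroxy-6-(hydroxymethyl)oxan-2-yl in place of 3,4-dihydroxy-5-(hydroxymethyl)oxolan-2-yl on an aromatic nitrogen. Among the measured compounds shown here, the one measured step that touches this position is the move from compound 1 to compound 2, which also exchanged the group on that aromatic nitrogen and stayed within the scatter. For the measured compounds named here, no other step bears on the question. Compound 3 is therefore expected to sit close to compound 2, and a 1.2-fold higher number from compound 2 to compound 3 (0.07 log units; within the scatter) is expected to remain inside the scatter. For compound 3 the estimate in this assay is 400 nM, with a range from 180 nM to 900 nM.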

Compound 3, half-maximal inhibitory concentration: 230 nM
Compound 3: the middle estimate sits 1.7-fold (0.24 log units) above what was measured, and the stated range covers the measured number.
By their numbers in this assay, from the lowest: compounds 1, 3 and 2 (each within the scatter of the next).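

Replacing 3,4-dihydroxy-5-(hydroxymethyl)oxolan-2-yl with 3,4,5-trihydroxy-6-(hydroxymethyl)oxan-2-yl on the aromatic nitrogen gives a 1.5-fold lower number from compound 2 to compound 3 (0.17 log units; within the scatter) in this assay, so the move from a five-membered to a six-membered sugar ring is not resolved by this read-out. Against the protected (5-(hydroxymethyl)-2,2-dimethyl-1,3-dioxolan-4-yl)methyl group, the same entering group gives a 1.2-fold higher number from compound 1 to compound 3 (0.08 log units; within the scatter) and so, with the earlier step, all three groups at this place now lie within the scatter of one another. No measurement at hand offers an explanation for this result.

As far as these compounds go, all three groups are oxygen-rich rings, so it remains open whether an aminoethyl chain or a carboxylic acid at this place would also stay within the scatter. From the compounds shown here alone, whether the three compounds would also stay this close on other cell lines is equally open.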